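Extending an Aryl Hydroxyl into an Amino-Alcohol Side Chain

A few compounds are considered here, and "the series" means these few. Any claim that something is new, unique, unknown or untested is made for them only; others in the source may bear on it.

This small series shares one core, carried by compound 3 `COc1ccc(-c2cc(-c3ccccc3)no2)c(O)c1`, which bears a free hydroxyl on its aromatic ring. All compounds were examined in a functional assay on the whole organism (blood, strain Sprague-Dawley albino) with Rattus norvegicus as the target, with stated times of 30 min and 24 h, at a dose of 100 mg/kg by the oral route; on this read-out lower numbers stand for less inhibition and higher numbers for more inhibition at the one dose given (going by the name of the read-out). Compound 3 stands without a single number: in this assay compound 3 gives "not determined" (no result reported). The same is true of compound 2 `CCOC(=O)CCCOc1cc(OC)ccc1-c1cc(-c2ccccc2)no1`, which in this assay gives "not determined" (no result reported). Going by the values given here, the only measured member is compound 1 `COc1ccc(-c2cc(-c3ccccc3)no2)c(OCCCN2CCCC2)c1`, whose side chain ends in a cyclic amine; in this assay compound 1 gives 11.2%, a low level of inhibition.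

Compound 4 `CCN(CC)CC(O)COc1cc(OC)ccc1-c1cc(-c2ccccc2)no1` differs from compound 3 by a single change: 3-(diethylamino)-2-hydroxypropyl in place of hydrogen on an oxygen on an aromatic ring. Among the compounds with values here, with no measured pair between compound 3 and compound 4, no step size can be quoted. Given that compound 1, the only amine-bearing analogue with a number, shows 11.2%, a similarly low level is expected for compound 4 rather than any marked rise. Compound 4 is therefore estimated to give about 15%, expected to fall between 0% and 40%.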

Compound 4, a percentage reported as inhibition, in the whole organism at one dose (the size of the read-out at that dose, not a potency): 11.4%
The estimate for compound 4 lay 3.6 percentage points above the measured number; measured number inside the range.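

With a second amine-bearing side chain now read in this assay, replacing 2-(pyrrolidin-1-yl)ethyl with 2-(diethylamino)-1-hydroxyethyl on the saturated chain carbon gives a number 0.2 percentage points higher from compound 1 to compound 4 (within the scatter), so these two side chains cannot be told apart on this read-out at the one dose given. This pair therefore shows that a ring-closed amine and an open diethylamino end carrying a hydroxyl can sit on this oxygen with no difference beyond the usual scatter. Nothing measured here explains why the two read alike.

Steps to compound 2 and compound 3 cannot be read, as neither has a single number, so the effect of adding any chain to the free hydroxyl remains unknown. Also open, on these data alone, is how a side chain ending in a carboxylic acid, with no amine at all, would compare with these two amines.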